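Replacing Nitro with Methylcarbamoyl: A Clearance Estimate

The compounds below may be only part of what the source reports. "The series", "measured", "known", "first", "only" and "open" are said of these compounds alone.

In an in vitro ADME assay on microsomes from liver (Homo sapiens) for metabolic stability, tested at 1 uM (on this read-out higher numbers stand for fast clearance and lower numbers for slow clearance), compound 1 `Cc1cc(/C=C/C#N)cc(C)c1Oc1cc(Nc2ccc(C#N)cc2)c(N)cc1[N+](=O)[O-]` gives 150 mL.min-1.g-1. Among the measured compounds shown here, the only other measured compound, compound 2 `Cc1cc(CCC#N)cc(C)c1Oc1cc(Nc2ccc(C#N)cc2)c(N)cc1C(N)=O`, gives 160 mL.min-1.g-1, which lies within the scatter of compound 1. Compound 3 `CNC(=O)c1cc(N)c(Nc2ccc(C#N)cc2)cc1Oc1c(C)cc(/C=C/C#N)cc1C` has not yet been measured. It carries methylcarbamoyl in place of nitro on an aromatic carbon of compound 1 (methylcarbamoyl in place of nitro on an aromatic carbon). For the measured compounds named here, no measured pair isolates this change, so the size of the step in this assay cannot be read directly from the data. The nearest guide is compound 2, which also lacks the nitro group and has an amide instead, at 160 mL.min-1.g-1, although it differs from compound 1 in its side chain as well. The expected step, a 1.1-fold lower number from compound 1 to compound 3 (0.05 log units; within the scatter), is none beyond the scatter. Compound 3 is estimated at 135 mL.min-1.g-1, with an expected range of 70 mL.min-1.g-1 to 240 mL.min-1.g-1.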

Compound 3, intrinsic clearance in microsomes: 150 mL.min-1.g-1
Estimate against measurement, compound 3: 1.1-fold (0.05 log units) below; low and high end bracket the measured number.
By their numbers in this assay, from the lowest: compounds 1, 3 and 2 (each within the scatter of the next).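

In this assay, among the compounds shown here, placing methylcarbamoyl in place of nitro on an aromatic carbon gives no change at the digits printed from compound 1 to compound 3 (within the scatter), the first step that isolates this change at this position. At this site, ortho to a large group and para to a (4-cyanophenyl)amino group, the exchange of nitro, with 3 heavy atoms and no hydrogen-bond donor, for methylcarbamoyl, with 4 heavy atoms and 1 hydrogen-bond donor, thus leaves this read-out within the scatter. Nothing in the data bears on why the read-out behaves this way.

As far as these compounds go, whether this holds for other groups at the same position, such as a carboxylic acid, an amine or a longer chain on the amide nitrogen, remains open. Also open, from the compounds shown here alone, is whether the same exchange would behave alike with a different side chain on the shared core.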